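The compounds below may be only part of what the source reports. "The series", "measured", "known", "first", "only" and "open" are said of these compounds alone.

Compound 1 `CCCC(CC(=O)N1CCC(Cn2c(C)nc3cnccc32)CC1)c1ccccc1` is the reference point of the pair measured so far. In a functional assay on the whole organism (arterial blood) with Rattus norvegicus as the target (on this read-out higher numbers stand for an effect only at larger amounts of compound and lower numbers for an effect already at smaller amounts), compound 1 gives 0.0079 mg/kg, the lowest of the two numbers at hand. Compound 2 `Cc1nc2cnccc2n1CC1CCN(C(=O)CC(C)(C)c2ccccc2)CC1` gives 0.012 mg/kg in this assay, and the step of a 1.5-fold higher number from compound 1 to compound 2 (0.18 log units; within the scatter) shows that exchanging the group on the saturated chain carbon bound to the carbonyl carbon left the read-out essentially unchanged.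

Compound 3 `CCOC(=O)C(CC(=O)N1CCC(Cn2c(C)nc3cnccc32)CC1)c1ccccc1` is not yet measured. Its difference from compound 1 is ethoxycarbonyl in place of propyl on a saturated chain carbon bound to an aromatic carbon and a saturated chain carbon. Among the measured compounds shown here, the only measured step, from compound 1 to compound 2, touches the same chain region but exchanges the whole hydrocarbon group, whereas the change to compound 3 replaces propyl by ethoxycarbonyl on a saturated chain carbon bound to an aromatic carbon and a saturated chain carbon. For the measured compounds named here, no measured step introduces two hydrogen-bond acceptors and a double bond outside aromatic rings at that place, so the record gives no direct guide. Going by the values given here, with the single available step inside the scatter, a modest step in this assay is expected for compound 3, with the higher number somewhat more likely than the lower, and the expected step is a 1.9-fold higher number from compound 1 to compound 3 (0.28 log units; within the scatter). For compound 3 the estimate in this assay is 0.015 mg/kg, expected to lie between 0.005 mg/kg and 0.05 mg/kg.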

Compound 3, dose for 50% inhibition: 0.17 mg/kg
Compound 3: the middle estimate sits 11-fold (1.05 log units) below what was measured; measured number outside the range, above it.
By their numbers in this assay, from the lowest: compounds 1 and 2 (each within the scatter of the next); then compound 3.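

On the saturated chain carbon bound to an aromatic carbon and a saturated chain carbon, ethoxycarbonyl in place of propyl gives a 22-fold higher number from compound 1 to compound 3 (1.33 log units; beyond the scatter) in this assay, so this position does not tolerate every exchange alike. The earlier pair, with a 1.5-fold higher number from compound 1 to compound 2 (0.18 log units; within the scatter), showed only that one hydrocarbon group could replace another in this chain region without a change beyond the scatter, whereas ethoxycarbonyl, with 2 hydrogen-bond acceptors and 1 double bond outside aromatic rings, is the first group shown to move the number beyond it. No measurement at hand bears on what lies behind this step.

The compounds shown leave open whether the step belongs to the ester as a whole or to one part of it, a question that a carboxylic acid, a methyl ester or a primary amide on the same carbon would help to separate. From the compounds shown here alone, it also remains open how far the hydrocarbon side of this position extends, which a longer chain than propyl or a methoxymethyl group at this place would test against the values of the series.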